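Selenium-linked ester series: nitrile for trifluoromethyl on selenium

The source may hold more compounds than are shown below. What is called first, only, known or untested is meant among the compounds shown, and "the series" means these compounds.

Two compounds of this series have been run in a functional assay on PC-3 cells (Homo sapiens) for cytotoxicity, read by MTT assay, with a stated time of 72 h; a higher number here means a weaker inhibitor, a lower number a stronger inhibitor. Compound 1 `COc1ccc2c(c1)c(CC(=O)OCCC[Se]C(F)(F)F)c(C)n2C(=O)c1ccc(Cl)cc1` gives 7800 nM in this assay. Compound 2 `CC1=C(CC(=O)OCCC[Se]C(F)(F)F)c2cc(F)ccc2/C1=C\c1ccc([S+](C)[O-])cc1`, which carries a different core, gives 11600 nM in this assay; the two numbers sit within the usual scatter of each other, so nothing separates compound 1 from compound 2 on the data so far.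

Compound 3 `COc1ccc2c(c1)c(CC(=O)OCCC[Se]C#N)c(C)n2C(=O)c1ccc(Cl)cc1` is not yet measured. It differs from compound 1 in one place: cyano in place of trifluoromethyl on a selenium. Among the compounds with values here, no measured pair shows this exchange, so its effect is unknown from the data in hand; the expectation is a step of no size beyond the scatter, in either direction, with the estimated change from compound 1 to compound 3 being a 1.1-fold higher number from compound 1 to compound 3 (0.04 log units; within the scatter). For compound 3 the estimate in this assay is 8500 nM, within a range from 3000 nM to 25000 nM.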

Compound 3, half-maximal inhibitory concentration: 21800 nM
For compound 3 the middle estimate is 2.6-fold (0.41 log units) below the measured one, and the stated range covers the measured number.
By their numbers in this assay, from the lowest: compounds 1, 2 and 3 (each within the scatter of the next, the first and the last beyond it).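

Within the data shown here, the selenium substituent is the first place where a single exchange can be read. In this assay cyano in place of trifluoromethyl on a selenium gives a 2.8-fold higher number from compound 1 to compound 3 (0.45 log units; beyond the scatter) and so moves the number beyond the scatter, which the comparison of compounds with different cores could not show. No available data explain this modest step.

On these data alone, this single pair rests on the core of compound 1, so whether the exchange gives a like step on the core of compound 2 remains open. Also open, as far as these compounds go, is whether a methyl or a phenyl on the selenium would read like trifluoromethyl, like cyano, or like neither.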